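This account rests on a few compounds, and the source may have more. Where it says the series, first, only, none or still open, it means among the compounds named here.

Compound 1 `CO[C@H]1C=C(COC(C)=O)C(=O)[C@@H]2O[C@@](C)(OC)[C@](C)(OC)O[C@@H]12` carries an acetyloxymethyl enone on a bicyclic diketal core; in an assay on isolated protein for inhibition of glutathione S-transferase A2 (Homo sapiens), read by spectrophotometry, with a stated time of 3 min (a higher number here means a weaker inhibitor, a lower number a stronger inhibitor), the result for compound 1 is "not determined" (no result reported), so no number is reported for it. Compound 2 `CO[C@]1(C)O[C@H]2[C@@H](OC/C=C/c3ccccc3)C=C(COC(C)=O)C(=O)[C@@H]2O[C@@]1(C)OC`, in which a (3-phenylprop-2-en-1-yl)oxy group sits on the saturated ring carbon, gives 94200 nM in this assay. Compound 2 thus stands as the only numbered entry here, and a weak one, with nothing to rank it against. Compound 3 `CO[C@]1(C)O[C@H]2[C@@H](OC/C=C(\C)CCC=C(C)C)C=C(COC(C)=O)C(=O)[C@@H]2O[C@@]1(C)OC` differs from compound 2 in one place: 2,6-dimethylhepta-1,5-dien-1-yl in place of 2-phenylethenyl on a saturated chain carbon bound to an oxygen on a saturated carbon. The ether oxygen and the allylic double bond are kept; a branched acyclic chain with a second double bond replaces the aromatic ring. Among the compounds with values here, with no measured pair to calibrate the change, the step of a 1.1-fold lower number from compound 2 to compound 3 (0.04 log units; within the scatter) is expected to stay within the usual scatter, in either direction. Compound 3 is therefore estimated at 85000 nM, within a range from 30000 nM to 250000 nM.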

Compound 3, half-maximal inhibitory concentration: 179000 nM
For compound 3 the middle estimate is 2.1-fold (0.32 log units) below the measured one, and the stated range covers the measured number.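

In this assay, within the data shown here, the exchange of 2-phenylethenyl for 2,6-dimethylhepta-1,5-dien-1-yl on a saturated chain carbon bound to an oxygen on a saturated carbon gives a 1.9-fold higher number from compound 2 to compound 3 (0.28 log units; within the scatter) and so offers the first comparison at this position. Across this one pair, the six-membered aromatic ring of carbon only can give way to a chain with no ring and 2 double bonds without a step beyond the scatter. Nothing measured here bears on the reason for this result.

As far as these compounds go, whether a free hydroxyl, a benzyl ether or a chain ending in an amine at this position would read differently stays open. From the compounds shown here alone, the role of the acetyloxymethyl group also stays open, since it is the same in both compounds with numbers.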